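Compound 3 to compound 4: a trifluoromethoxy swap

This account rests on a few compounds, and the source may have more. Where it says the series, first, only, none or still open, it means among the compounds named here.

In a functional assay on LNCaP cells (Homo sapiens) for antiproliferative activity, read by propidium iodide staining, with a stated time of 96 h (a higher number here means a weaker inhibitor, a lower number a stronger inhibitor), compound 1 (`CC(O)(CSc1cccc(S(F)(F)(F)(F)F)c1)C(=O)Nc1ccc([N+](=O)[O-])c(C(F)(F)F)c1`) gives 8600 nM and compound 2 (`CC(O)(CSc1ccc(S(F)(F)(F)(F)F)cc1)C(=O)Nc1ccc(S(F)(F)(F)(F)F)cc1`) gives 18300 nM. Compound 3 (`CC(O)(COc1ccc(S(F)(F)(F)(F)F)cc1)C(=O)Nc1cccc(S(F)(F)(F)(F)F)c1`) gives 8000 nM, which is within the scatter of compound 1 and lower than compound 2 by more than the scatter. Compound 4 (`CC(O)(COc1ccc(OC(F)(F)F)cc1)C(=O)Nc1cccc(S(F)(F)(F)(F)F)c1`) differs from compound 3 at one place: a group of 5 heavy atoms (1 carbon, 1 oxygen, 3 fluorine; no ring) in place of a group of 6 heavy atoms (5 fluorine, 1 sulfur; no ring), on an aromatic carbon. The incoming trifluoromethoxy sits on an aromatic carbon, para to a large group. Among the measured compounds shown here, no measured pair isolates this change, so the expectation stays close to compound 3 at 8000 nM. No step beyond the scatter is expected in this assay, with an estimated 1.1-fold higher number from compound 3 to compound 4 (0.05 log units; within the scatter). For compound 4 the expected value is 9000 nM, with an estimated range of 4000 nM to 20000 nM.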

Compound 4, half-maximal inhibitory concentration: 12700 nM
Compound 4: middle estimate off by 1.4-fold (0.15 log units), on the low side, and the stated range covers the measured number.
By their numbers in this assay, from the lowest: compounds 3, 1, 4 and 2 (each within the scatter of the next, the first and the last beyond it).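

In this assay, the step is a 1.6-fold higher number from compound 3 to compound 4 (0.20 log units; within the scatter), so the two compounds cannot be told apart at this aromatic carbon, para to a large group. Compound 3 and compound 4 therefore show that trifluoromethoxy can stand in place of the group of 6 heavy atoms (5 fluorine, 1 sulfur) without a step beyond the scatter. No measured data here bear on the reason for this result.

From the compounds shown here alone, whether an amine, a nitrile or a carboxylic acid on this aromatic carbon would keep the value in the same range remains open. Also open, going by these compounds, is whether the same swap gives a similar step on a different core, such as that of compound 2.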